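The source may hold more compounds than are shown below. What is called first, only, known or untested is meant among the compounds shown, and "the series" means these compounds.

Measured so far:
compound 1 `COc1ccc(C(O)C2OC(=O)c3c(OC)cc(OC)cc32)cc1`: > 10000 nM
compound 2 `COc1cc(OC)c2c(c1)C(C(O)c1ccc(OCc3ccccc3)cc1)OC2=O`: > 10000 nM
compound 3 `COc1cc(OC)c2c(c1)C(C(O)c1ccc(OCc3ccc(F)cc3)cc1)OC2=O`: 760 nM

In a functional assay on RAW264.7 cells (Mus musculus) for inhibition, read by Griess assay, with stated times of 1 h and 24 h (on this read-out higher numbers stand for weaker inhibition and lower numbers for stronger inhibition), compound 1 gives > 10000 nM, which is a limit of the assay rather than a number. Compound 2 likewise reaches only a limit, > 10000 nM. Among the compounds with values here, compound 3 is the one compound with a numeric value, 760 nM. Compound 1 therefore stands at the limit of > 10000 nM in this assay, at which 2 of the 3 values shown sit, the weak end of what is shown.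

Compound 4 `COc1cc(OC)c2c(c1)C(C(O)c1ccc(OCc3ccc(OC(F)(F)F)cc3)cc1)OC2=O` differs from compound 1 by 4-(trifluoromethoxy)phenyl in place of hydrogen on a saturated chain carbon bound to an oxygen on an aromatic ring. Within the data shown here, two measured steps bear on this change. The step that the two limits leave unreadable from compound 1 to compound 2 has no readable size. The step of an at least 13-fold lower number from compound 1 to compound 3 (1.11 log units; beyond the scatter) is large, and the step of an at least 13-fold lower number from compound 2 to compound 3 (1.11 log units; beyond the scatter) shows that the fluoro on the entering ring separates the two outcomes. Compound 4 carries a trifluoromethoxy group on that ring instead, so its result could sit anywhere between those two cases. In this assay compound 4 is expected to give a step of an at least 4.0-fold lower number from compound 1 to compound 4 (0.60 log units; beyond the scatter), an estimate of 2500 nM with a range from 600 nM to 10000 nM.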

Compound 4, half-maximal inhibitory concentration: 8140 nM
Beside the measured number, compound 4's estimate is 3.3-fold (0.51 log units) below it; low and high end bracket the measured number.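

In this assay, trifluoromethoxy in place of fluoro on an aromatic carbon gives an 11-fold higher number from compound 3 to compound 4 (1.03 log units; beyond the scatter), so the gain seen with fluoro does not extend to every group on the entering ring. Against the two weakest-reading compounds, the steps are an at least 1.2-fold lower number from compound 1 to compound 4 (0.08 log units; that floor lies within the scatter) and an at least 1.2-fold lower number from compound 2 to compound 4 (0.08 log units; that floor lies within the scatter), so neither step shows a real gain over those compounds. Compound 1 and compound 2 give only a limit rather than a number, which leaves the weak end loosely fixed: the limit of > 10000 nM in this assay, at which 2 of the 4 values shown sit.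

Going by these compounds, it remains open whether another group in the same place on the entering ring, such as chloro, a nitrile or an amine, would behave like fluoro or like trifluoromethoxy. The compounds shown also leave open what a longer chain in place of the entering group's link to the oxygen would do.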